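The source may report more compounds than this note shows. Statements on the series, on what has been measured and on what is new or still open speak of the compounds shown alone.

Series notes, aryloxyacetamides and related tertiary amides.

Three compounds have numbers in an assay on HEK293 cells for agonist activity at transient receptor potential cation channel subfamily M member 8 (Homo sapiens), read by fluorescence and calcium flux, with a stated time of 15 min; a lower number here means that less compound is needed, a higher number that more compound is needed for the effect. Compound 1 `Cc1ccc(OCC(=O)N(Cc2cccs2)c2cnn(C)c2)cc1` gives 63000 nM. Compound 2 `CCN(Cc1ccccc1)C(=O)COc1ccc(C)cc1` gives 1880 nM. Compound 3 `CCN(Cc1cccs1)C(=O)CCc1ccc(C)cc1` gives 93 nM. Within this set compound 2 stands second highest: its nearest neighbour is compound 3, whose number is lower by a margin beyond the scatter, and the furthest is compound 1, whose number is higher, again beyond the scatter. None of these three pairs differs in a single place, so no step is shown between them; the values alone mark out the spread of the series so far.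

Compound 4 `CCN(Cc1cn[nH]c1)C(=O)COc1ccc(C)cc1` has not yet been measured. It is reached from compound 2 by a change in one place, (1H-pyrazol-4-yl in place of phenyl on a saturated chain carbon bound to an amide-type nitrogen). Within the data shown here, compound 1, the one member of the series carrying a pyrazolyl group on the saturated chain carbon bound to the amide-type nitrogen, gives the highest number of the three, though it differs from compound 2 in more than that one place and is not a direct guide.

The expectation for compound 4 is a move toward higher numbers, beyond the scatter, in the step of a 4.3-fold higher number from compound 2 to compound 4 (0.63 log units; beyond the scatter). The estimate for compound 4 is 8000 nM, with a range from 2500 nM to 30000 nM.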

Compound 4, half-maximal effective concentration: "active" (no number reported)
Compound 4 has no reported number here, and the estimate cannot be compared.
By their numbers in this assay, from the lowest: compound 3; then compound 2; then compound 1.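

Among these compounds, compound 4 stands in this assay with the entry "active" (no number reported) and so no step from compound 2 can be read. As far as these compounds go, whether 1H-pyrazol-4-yl in place of phenyl moves the number up, down or not at all stays open, as does the rank of compound 4 in the series. No evidence at hand bears on this result.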